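The source may report more compounds than this note shows. Statements on the series, on what has been measured and on what is new or still open speak of the compounds shown alone.

Measured so far:
- compound 1, `CCc1cc(C(C)=O)c(O)cc1OCCCCCCC(C)(C)c1nnn[nH]1`, in an assay on isolated protein for binding affinity to leukotriene B4 receptor 1 (Homo sapiens), tested at 1 uM (on this read-out lower numbers stand for less inhibition and higher numbers for more inhibition at the one concentration tested (going by the name of the read-out)), gives 67%.
- compound 2, `CCc1cc(C(C)=O)c(O)cc1OCCCCCC[S+](C)[O-]`, in this assay gives 50%.

Compound 2 stands lowest of the two numbers shown; its nearest neighbour is compound 1, whose value is higher by a step beyond the usual scatter. For the measured compounds named here, the only step available is the one between these two, a number 17 percentage points lower from compound 1 to compound 2 (beyond the scatter), which accompanied the exchange of a five-membered aromatic ring with four hetero atoms for a short chain-end group without a ring.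

Compound 3, `CCc1cc(C(C)=O)c(O)cc1OCCCCCCC(=O)Nc1nn[nH]n1`, is the next structure to be measured. It differs from compound 2 in this way: a group of 8 heavy atoms (2 carbon, 5 nitrogen, 1 oxygen; one five-membered aromatic ring with 4 hetero atoms) in place of a group of 3 heavy atoms (1 carbon, 1 oxygen, 1 sulfur; no ring), on a saturated chain carbon, six bonds along the chain from an oxygen on an aromatic ring. This change runs in the opposite direction to the measured step. It brings a five-membered aromatic ring with four hetero atoms back to the chain end, now joined through a carbamoyl link rather than directly. On that basis, a rise of roughly the size of a number 17 percentage points lower from compound 1 to compound 2 (beyond the scatter) is expected, though the new link adds uncertainty, so the range is kept wide.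

The estimated step from compound 2 to compound 3 is a number 15 percentage points higher from compound 2 to compound 3 (beyond the scatter). Compound 3 is expected to give 65% in this assay, with a likely range from 42% to 85%.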

Compound 3, a percentage reported as inhibition, at one concentration (the size of the read-out at that concentration, not a potency): 83%
Compound 3: middle estimate off by 18 percentage points, on the low side, and the stated range covers the measured number.
By their numbers in this assay, from the lowest: compound 2; then compound 1; then compound 3.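

At the saturated chain carbon six bonds along the chain from the oxygen on the aromatic ring, (2H-tetrazol-5-yl)carbamoyl in place of the small ring-free end group of compound 2 gives a number 33 percentage points higher from compound 2 to compound 3 (beyond the scatter), a large step that shows a second ring-bearing end group standing clearly above that small group. The new comparison between two ring-bearing end groups gives a number 16 percentage points higher from compound 1 to compound 3 (beyond the scatter), so in this assay the result depends on more than the presence of the five-membered aromatic ring: (2H-tetrazol-5-yl)carbamoyl and 1-(1H-tetrazol-5-yl)-1-methylethyl are not interchangeable, and compound 3 stands highest of the three. Nothing measured here explains this order.

On these data alone, it remains open how much of the rise belongs to the carbamoyl link and how much to the ring, which a carboxylic acid or a simple primary amide at the chain end could help separate. A shorter or longer chain carrying (2H-tetrazol-5-yl)carbamoyl would show whether this end group depends on its distance from the shared core.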